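The compounds below may be only part of what the source reports. "The series", "measured", "known", "first", "only" and "open" are said of these compounds alone.

In a functional assay on A549 cells (Homo sapiens) for cytotoxicity, read by MTT assay, with a stated time of 48 h (on this read-out higher numbers stand for an effect only at larger amounts of compound and lower numbers for an effect already at smaller amounts), three compounds built on a shared core have been measured. Compound 1 `CO[C@H]1O[C@H](COc2ccc3c(c2)CCCC3)[C@@H](O)[C@H](O)[C@H]1Oc1cccc(C(C)C)c1` gives 40000 nM, compound 2 `CO[C@H]1O[C@H](COc2ccc(C3CCCCC3)cc2)[C@@H](O)[C@H](O)[C@H]1Oc1ccc(OC2CCCCC2)cc1` gives 12000 nM, and compound 3 `CO[C@H]1O[C@H](COc2ccc(C3CCCCC3)cc2)[C@@H](O)[C@H](O)[C@H]1Oc1cccc2c1CCCC2` gives 28000 nM. Compound 3 therefore stands within the scatter of compound 1, while compound 2 lies beyond the scatter on the lower side of compound 3.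

The next compound, compound 4 `CO[C@H]1O[C@H](COc2ccc(C3CCCCC3)cc2)[C@@H](O)[C@H](O)[C@H]1Oc1ccc2c(c1)CCCC2`, has the same atoms as compound 3, joined differently: 1,2,3,4-tetrahydronaphthalen-6-yl in place of 1,2,3,4-tetrahydronaphthalen-5-yl on an oxygen on a saturated carbon. In words, 1,2,3,4-tetrahydronaphthalen-6-yl takes the place of 1,2,3,4-tetrahydronaphthalen-5-yl on an oxygen on a saturated carbon. Among the compounds with values here, no measured pair isolates this change, so the expectation rests only on the narrow spread of values, with compound 2 at 12000 nM as the lowest number available in this assay. The expected change, a 1.3-fold lower number from compound 3 to compound 4 (0.10 log units; within the scatter), is small, leaning toward a lower number and not expected to exceed the scatter. For compound 4 the estimated value is 22000 nM, with an expected range from 10000 nM to 46000 nM.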

Compound 4, half-maximal effective concentration: 17000 nM
Beside the measured number, compound 4's estimate is 1.3-fold (0.11 log units) above it, within the range that was stated.
By their numbers in this assay, from the lowest: compounds 2, 4, 3 and 1 (each within the scatter of the next, the first and the last beyond it).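

Within the data shown here, compound 3 and compound 4 give the first pair that differs in one place, and it isolates the point at which the bicyclic group is joined, with no atoms gained or lost. In this assay, 1,2,3,4-tetrahydronaphthalen-6-yl in place of 1,2,3,4-tetrahydronaphthalen-5-yl on an oxygen on a saturated carbon gives a 1.6-fold lower number from compound 3 to compound 4 (0.22 log units; within the scatter), so this assay does not tell the two attachments apart. Nothing available accounts for this result or explains why the step is this size.

On these data alone, what a different kind of group on this oxygen, such as an amine or a carboxylic acid, would do remains open. As far as these compounds go, it is also open whether this step would stay the same with a different group elsewhere on the shared core.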